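Alkenyl amide variation on a shared core

A few compounds are considered here, and "the series" means these few. Any claim that something is new, unique, unknown or untested is made for them only; others in the source may bear on it.

Compound 3 `C/C=C/C(=O)Nc1cccc(Oc2nc(Nc3cccc(C#N)c3)nc3ccsc23)c1` gives 20100 nM in a functional assay on A-431 cells (Homo sapiens) for inhibition, read by MTT assay, with a stated time of 72 h (on this read-out higher numbers stand for weaker inhibition and lower numbers for stronger inhibition), the highest number among the measured compounds. Nearest to it is compound 1 `COc1ccc(Nc2nc(Oc3cccc(NC(=O)C=C(C)C)c3)c3sccc3n2)cc1` at 17600 nM, a gap within the scatter; furthest is compound 2 `C=CC(=O)Nc1cccc(Oc2nc(Nc3cccc(C#N)c3)nc3ccsc23)c1` at 3790 nM, a gap beyond the scatter.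

Compound 4 `CC(C)=CC(=O)Nc1cccc(Oc2nc(Nc3cccc(C#N)c3)nc3ccsc23)c1` differs from compound 3 in one place: 2-methylprop-1-en-1-yl in place of prop-1-en-1-yl on a carbonyl carbon. Among the measured compounds shown here, no measured pair shows exactly this change. For the measured compounds named here, the one measured step on the same carbonyl carbon is a 5.3-fold higher number from compound 2 to compound 3 (0.72 log units; beyond the scatter), which went the way of a weaker read-out when the alkenyl chain grew. Compound 1, which already carries the 2-methylprop-1-en-1-yl group but a different aryl amine, gives 17600 nM against 20100 nM for compound 3, a pair within the scatter of each other, so the enlarged alkenyl group is not seen to move the number on its own.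

On this basis the step to compound 4 is expected to be small, at most a modest move toward a higher number, a 1.2-fold higher number from compound 3 to compound 4 (0.09 log units; within the scatter). Compound 4 is therefore estimated at 25000 nM, with a range from 10000 nM to 60000 nM.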

Compound 4, half-maximal inhibitory concentration: 28300 nM
For compound 4 the middle estimate is 1.1-fold (0.05 log units) below the measured one; the measured number falls inside the stated range.
By their numbers in this assay, from the lowest: compound 2; then compounds 1, 3 and 4 (each within the scatter of the next).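

In this assay the extra methyl on the alkenyl group does not separate the two substituted amides: a 1.4-fold higher number from compound 3 to compound 4 (0.15 log units; within the scatter) stays within the scatter, so prop-1-en-1-yl and 2-methylprop-1-en-1-yl on this carbonyl carbon read alike. Vinyl alone stands apart at this position, since a 7.5-fold higher number from compound 2 to compound 4 (0.87 log units; beyond the scatter) lies beyond the scatter, as does a 5.3-fold higher number from compound 2 to compound 3 (0.72 log units; beyond the scatter), and both substituted alkenyl groups therefore sit on the weaker side of the vinyl amide. The aryl group on the amine also leaves the number unmoved while 2-methylprop-1-en-1-yl stays in place, with a 1.6-fold higher number from compound 1 to compound 4 (0.21 log units; within the scatter) inside the scatter for 3-cyanophenyl in place of 4-methoxyphenyl.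

The compounds shown do not tell how a saturated ethyl chain, an alkyne or an alkenyl chain ending in an amine would read on the same carbonyl carbon, nor whether 3-cyanophenyl and 4-methoxyphenyl would also read alike with vinyl there. Nothing on hand offers an explanation for any of these steps.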